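Swapping Acetamido for Dimethylamino on a Fused Core

This account rests on a few compounds, and the source may have more. Where it says the series, first, only, none or still open, it means among the compounds named here.

Compound 1 `CN1CCC[C@H]1[C@H]1COc2ccc(N)cc2O1` gives 180 nM in an assay on membranes from HEK293 cells for displacement of a labelled ligand from Neuronal acetylcholine receptor; alpha3/beta4 (Homo sapiens), with a stated time of 5 min; a lower number here means a stronger inhibitor, a higher number a weaker inhibitor.
Compound 2 `CN1CCC[C@H]1[C@H]1COc2ccc([N+](=O)[O-])cc2O1` gives 2100 nM in this assay.
Compound 3 `CC(=O)Nc1ccc2c(c1)O[C@@H]([C@@H]1CCCN1C)CO2` gives 8700 nM in this assay.

Compound 3 shows the highest number of the three measured; the steps of a 48-fold higher number from compound 1 to compound 3 (1.68 log units; beyond the scatter) and a 4.1-fold higher number from compound 2 to compound 3 (0.62 log units; beyond the scatter) both lead up to it. Compound 4 `CN(C)c1ccc2c(c1)O[C@@H]([C@@H]1CCCN1C)CO2` differs from compound 3 by dimethylamino in place of acetamido on an aromatic carbon. The step of a 48-fold higher number from compound 1 to compound 3 (1.68 log units; beyond the scatter) bears most on this change: putting an acetyl on the ring nitrogen raised the number a great deal, and compound 4 removes that acetyl again while adding two methyls. The step of a 4.1-fold higher number from compound 2 to compound 3 (0.62 log units; beyond the scatter) touches the same aromatic carbon. A clear fall in the number is therefore expected, a 12-fold lower number from compound 3 to compound 4 (1.09 log units; beyond the scatter), though not all the way back to compound 1. Compound 4 is estimated at 700 nM, with a range from 150 nM to 3500 nM.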

Compound 4, inhibition constant: 25000 nM
Compound 4: the middle estimate sits 36-fold (1.55 log units) below what was measured, and the stated range ends below it.
By their numbers in this assay, from the lowest: compound 1; then compound 2; then compound 3; then compound 4.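

Taking the acetyl off compound 3 did not bring back the low number of compound 1: with two methyls on that nitrogen, the number rose further (a 2.9-fold higher number from compound 3 to compound 4 (0.46 log units; beyond the scatter)). Compound 4 also sits above the nitro compound (a 12-fold higher number from compound 2 to compound 4 (1.08 log units; beyond the scatter)) and far above the free amino compound (a 140-fold higher number from compound 1 to compound 4 (2.14 log units; beyond the scatter)), so in this assay both acetyl and two methyls on this nitrogen raise the number compared with amino. No measurement shown explains this order.
The compounds shown leave open whether methylamino, with one methyl, would stay near compound 1 or move toward compound 4. As far as these compounds go, how a hydroxyl on the same aromatic carbon would compare also remains open.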